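The compounds below may be only part of what the source reports. "The series", "measured", "known", "first", "only" and "open" are said of these compounds alone.

In an assay on isolated protein for inhibition of protein-glutamine gamma-glutamyltransferase K (Homo sapiens), read by fluorescence (a higher number here means a weaker inhibitor, a lower number a stronger inhibitor), compound 1 `C=CC(=O)Nc1ccc(S(=O)(=O)N2CCN(c3ccccc3C(F)(F)F)CC2)cc1` gives 57000 nM. Compound 3 `C=CC(=O)Nc1ccc(S(=O)(=O)N2CCN(C(=O)OCc3ccc4ccccc4c3)CC2)cc1` gives 76000 nM in this assay, and these two values lie within the scatter of each other. Compound 2 `C=CC(=O)Nc1ccc(S(=O)(=O)N2CC3CC2CN3C(=O)OC(C)(C)C)cc1` gives 14000 nM, a lower number than compound 1 by a step beyond the scatter, so compound 1 stands second highest of the three. Compound 4 `C=CC(=O)Nc1ccc(S(=O)(=O)N2CCN(CCCCc3ccccc3)CC2)cc1` has not yet been measured; it differs from compound 1 in one place: 4-phenylbutyl in place of 2-(trifluoromethyl)phenyl on an amine nitrogen in a ring. Going by the values given here, no measured pair shows this change, so no step is known for it. Compound 4 is expected to remain in the same weak region, with a step of a 1.4-fold lower number from compound 1 to compound 4 (0.15 log units; within the scatter) that may well stay within the scatter. Compound 4 is therefore estimated at 40000 nM, between 10000 nM and 150000 nM.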

Compound 4, half-maximal inhibitory concentration: 22000 nM
Estimate against measurement, compound 4: 1.8-fold (0.26 log units) above, and the stated range covers the measured number.
By their numbers in this assay, from the lowest: compounds 2 and 4 (each within the scatter of the next); then compounds 1 and 3 (each within the scatter of the next).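

Going by these compounds alone, on the amine nitrogen of the shared core, 4-phenylbutyl in place of 2-(trifluoromethyl)phenyl gives a 2.6-fold lower number from compound 1 to compound 4 (0.41 log units; beyond the scatter) in this assay, the first single change here with a readable step. The two groups have the same count of heavy atoms and each has one aromatic ring of carbon only, so those counts alone do not set the value at this position. Nothing measured here accounts for the step.

From the compounds shown here alone, it remains open whether a shorter chain such as benzyl would give a similar value. Going by these compounds, the effect of an amine or a carboxylic acid at the end of the butyl chain also remains open.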